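Dechlorination of the hydrazone compound 2 in the series

This account rests on a few compounds, and the source may have more. Where it says the series, first, only, none or still open, it means among the compounds named here.

Measured so far:
compound 1, `COc1ccc(OC)c(/C=C/c2nnc(Nc3ccc(Cl)cc3)o2)c1`, 7170 nM
compound 2, `COc1ccc(OC)c(/C=C/C(=O)N/N=C/c2ccc(Cl)cc2)c1`, 58.1 nM

In a functional assay on SK-MEL-5 cells (Homo sapiens) for antiproliferative activity, read by sulforhodamine B assay, with a stated time of 48 h (on this read-out higher numbers stand for weaker inhibition of growth and lower numbers for stronger inhibition of growth), compound 1 gives 7170 nM, while compound 2 gives 58.1 nM. Compound 2 holds the lowest of the two measured numbers; its nearest neighbour is compound 1, whose number lies far above it, well beyond the scatter. For the measured compounds named here, no single-point step links compound 1 and compound 2, so their two values are all that can be compared.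

Compound 3 is `COc1ccc(OC)c(/C=C/C(=O)N/N=C/c2ccccc2)c1`. It differs from compound 2 by hydrogen in place of chloro on an aromatic carbon. Going by the values given here, no measured pair shows this change, so its size cannot be read from existing data. The step from compound 2 to compound 3 is expected to be modest, a 1.9-fold higher number from compound 2 to compound 3 (0.28 log units; within the scatter), tending toward weaker inhibition of growth but possibly within the scatter. Compound 3 is estimated at 110 nM, with a range from 30 nM to 400 nM.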

Compound 3, concentration for 50% growth inhibition: 2940 nM
Beside the measured number, compound 3's estimate is 27-fold (1.43 log units) below it; the measured number lies above the stated range.
By their numbers in this assay, from the lowest: compound 2; then compound 3; then compound 1.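

In this assay the change from 4-chlorophenyl to phenyl gives a 51-fold higher number from compound 2 to compound 3 (1.70 log units; beyond the scatter) and counts as a large step. For the compounds shown here, this is the first single-place comparison, and it shows that the activity of the hydrazone compound 2 depends strongly on the chloro group on this aromatic carbon, para to a large group: losing one chlorine atom, with the rest of the structure unchanged, is enough to weaken growth inhibition well beyond the scatter. No measurement at hand accounts for the size of this step.

From the compounds shown here alone, whether the chlorine atom itself is needed at this place, or whether a fluorine atom, a methoxy group or an amine would serve as well, remains open. Also open, going by these compounds, is whether the same change would have a step of like size on the core of compound 1.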